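One Side-Chain Change, Tested on a Second Core

The compounds below may be only part of what the source reports. "The series", "measured", "known", "first", "only" and "open" are said of these compounds alone.

Compound 1 `COc1cc2c(Oc3ccc(NC(=O)c4cn(-c5ccc(Cl)cc5)cn4)cc3F)ccnc2cc1OCCCN1CCN(C)CC1` and compound 2 `COc1cc2c(Oc3ccc(NC(=O)c4cn(-c5ccc(Cl)cc5)cn4)cc3F)ccnc2cc1OCCCN1CCCCC1` share a core and differ only at the end of a short chain. In a functional assay on HT-29 cells (Homo sapiens) for cytotoxicity, read by MTT assay, with a stated time of 72 h (a higher number here means a weaker inhibitor, a lower number a stronger inhibitor), compound 1 gives 1350 nM, while compound 2 gives 2780 nM. The change, (piperidin-1-yl in place of 4-methylpiperazin-1-yl on a saturated chain carbon, three bonds along the chain from an oxygen on an aromatic ring), produced a 2.1-fold higher number from compound 1 to compound 2 (0.31 log units; beyond the scatter). Compound 3 `COc1cc2c(Oc3ccc(NC(=O)/C=C/S(=O)(=O)c4ccccc4OC)cc3F)ccnc2cc1OCCCN1CCN(C)CC1` carries the same side chain as compound 1 on a different core; the difference between the two cores is not broken down here. In this assay compound 3 gives 270 nM, the lowest of the three numbers. Compound 4 `COc1cc2c(Oc3ccc(NC(=O)/C=C/S(=O)(=O)c4ccccc4OC)cc3F)ccnc2cc1OCCCN1CCCCC1` has not been measured; it differs from compound 3 by piperidin-1-yl in place of 4-methylpiperazin-1-yl on a saturated chain carbon, three bonds along the chain from an oxygen on an aromatic ring, the same change seen between compound 1 and compound 2. The step is expected to be about a 2.1-fold higher number from compound 3 to compound 4 (0.32 log units; beyond the scatter) because a 2.1-fold higher number from compound 1 to compound 2 (0.31 log units; beyond the scatter) was modest. Compound 4 is therefore estimated at 570 nM, with a likely range from 300 nM to 1100 nM.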

Compound 4, half-maximal inhibitory concentration: 660 nM
The estimate for compound 4 lay 1.2-fold (0.06 log units) below the measured number; the range from low to high includes it.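

In this assay the swap of 4-methylpiperazin-1-yl for piperidin-1-yl gives a 2.4-fold higher number from compound 3 to compound 4 (0.39 log units; beyond the scatter) on the second core, and the two steps agree in direction and size: the same change on two cores in this assay, a 2.1-fold higher number (0.31 log units; beyond the scatter) from compound 1 to compound 2 and a 2.4-fold higher number (0.39 log units; beyond the scatter) from compound 3 to compound 4, 1.2-fold (0.07 log units) apart, within the scatter of two such steps. So on these two cores the change carried over, and the earlier step was a fair guide to the later one. Among the compounds shown here, with only two pairs in one cell assay, this does not show that the change would carry over to other cores, nor does it explain why the number rises.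

The compounds shown leave open what a morpholine ring or a dimethylamino group would give at the end of the same chain. From the compounds shown here alone, how a shorter or longer chain would behave also remains open.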